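A Pyridyl Swap on a Benzyl Arm at the Cytotoxicity Ceiling

The compounds below may be only part of what the source reports. "The series", "measured", "known", "first", "only" and "open" are said of these compounds alone.

Compound 3, with the structure `COc1cc(Cn2c(=O)c(C3=CS(=O)(=O)c4cc(NS(C)(=O)=O)ccc4N3)c(O)c3cc(F)ccc32)ccc1F`, was tested in an ADME assay on 2209-23 cells (Homo sapiens) for cytotoxicity, read by WST assay; on this read-out lower numbers stand for higher toxicity in this test and higher numbers for lower toxicity in this test. In this assay compound 3 gives > 50000 nM, which is a limit of the assay and not a number. Its neighbours sit at the same ceiling. Compound 1, `CS(=O)(=O)Nc1ccc2c(c1)S(=O)(=O)C=C(c1c(O)c3cc(F)ccc3n(Cc3ccccc3)c1=O)N2`, gives > 50000 nM in this assay, again a limit. Compound 2, `Cc1cc(Cn2c(=O)c(C3=CS(=O)(=O)c4cc(NS(C)(=O)=O)ccc4N3)c(O)c3cc(F)ccc32)ccc1F`, gives > 50000 nM in this assay, also a limit. Every measured value therefore rests on (the limit of > 50000 nM in this assay, at which 3 of the 3 values shown sit), and none of the three steps can be read: a step that the two limits leave unreadable from compound 1 to compound 3, a step that the two limits leave unreadable from compound 2 to compound 3, and a step that the two limits leave unreadable from compound 1 to compound 2.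

Compound 4, `CS(=O)(=O)Nc1ccc2c(c1)S(=O)(=O)C=C(c1c(O)c3cc(F)ccc3n(Cc3cccnc3)c1=O)N2`, carries the change (pyridin-3-yl in place of 4-fluoro-3-methoxyphenyl on a saturated chain carbon bound to an aromatic nitrogen). The three steps that bear on it, all of which move a group on the same saturated chain carbon bound to an aromatic nitrogen or on its ring, give no readable size, so no direction can be drawn from them. Compound 4 is expected to sit at the same limit, with an estimated value of 50000 nM, ranging from 20000 nM to 100000 nM. This estimate implies an expected a number no higher from compound 3 to compound 4 (the limit leaves the size open).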

Compound 4, half-maximal cytotoxic concentration: > 50000 nM
Compound 4: no number, only a limit; the forecaster's own chance of this, stated with the estimate: 80%; the middle value sits exactly at the limit.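

Like compound 1, compound 2 and compound 3, compound 4 gives only a limit and not a number in this assay, so none of its steps to them can be read: the limit of > 50000 nM in this assay, at which 4 of the 4 values shown sit. The compounds shown leave open how the four compare in cytotoxicity, and whether any change on the saturated chain carbon bound to an aromatic nitrogen shifts it.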